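Bromine position swap on the benzylthio purine nucleoside

The source may report more compounds than this note shows. Statements on the series, on what has been measured and on what is new or still open speak of the compounds shown alone.

Of the compounds shown here, two have been measured in an assay on isolated protein for binding affinity to Equilibrative nucleoside transporter 1 (Homo sapiens); a higher number here means a weaker inhibitor, a lower number a stronger inhibitor. Compound 1 `O=[N+]([O-])c1cccc2c1CCN(c1ncnc3c1nc1n3[C@@H]3O[C@H](CO1)[C@@H](O)[C@H]3O)C2` gives 7410000 nM. Compound 2 `Nc1nc(SCc2cccc(Br)c2)c2ncn([C@@H]3O[C@H](CO)[C@@H](O)[C@H]3O)c2n1` gives 2880 nM, the lower of the two numbers, and compound 1 sits well above it. The two differ in many places at once, so no single step can be read from them.

Compound 3 `Nc1nc(SCc2ccc(Br)cc2)c2ncn([C@@H]3O[C@H](CO)[C@@H](O)[C@H]3O)c2n1` is the untested partner of compound 2. The change is 4-bromophenyl in place of 3-bromophenyl on a saturated chain carbon bound to a sulfur; the same atoms are joined differently, and nothing else moves. For the measured compounds named here, for a change of this kind with no measured precedent, the expected step from compound 2 to compound 3 is small, a 1.2-fold lower number from compound 2 to compound 3 (0.06 log units; within the scatter), and may not exceed the scatter in either direction. In this assay compound 3 is therefore estimated at 2500 nM, with a plausible range from 700 nM to 9000 nM.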

Compound 3, half-maximal inhibitory concentration: 813 nM
Compound 3: the middle estimate sits 3.1-fold (0.49 log units) above what was measured; low and high end bracket the measured number.
By their numbers in this assay, from the lowest: compound 3; then compound 2; then compound 1.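

The bromine position on the (bromobenzyl)sulfanyl group matters in this assay: 4-bromobenzyl in place of 3-bromobenzyl gives a 3.5-fold lower number from compound 2 to compound 3 (0.55 log units; beyond the scatter), although the atoms are the same and only their connection differs. For the compounds shown here, this is the first pair that differs in one place, so it gives the first direct reading at this position, which the comparison with compound 1 could not provide. No available measurement explains the step.

As far as these compounds go, it remains open whether the step depends on bromine itself or would also appear with another group, such as chlorine, methoxy or a carboxylic acid, at the same ring position. Also open, from the compounds shown here alone, is whether a longer chain in place of the benzyl carbon, or removal of the amine from the shared core, would preserve the same preference.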